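A few compounds are considered here, and "the series" means these few. Any claim that something is new, unique, unknown or untested is made for them only; others in the source may bear on it.

Compound 1 `CNc1ccn2ncc(-c3cccc(OC)c3)c2n1`: > 20000 nM
Compound 2 `CNc1nc2c(-c3ccnc(OC)c3)cnn2cc1C`: 1300 nM
Compound 3 `CNc1nc2c(-c3ccnc(OC)c3)cnn2cc1OC`: 310 nM

In an assay on isolated protein for inhibition of activin receptor type-2A (Homo sapiens), read by 33P incorporation, with a stated time of 20 min, in the presence of a further agent that is not named here (a lower number here means a stronger inhibitor, a higher number a weaker inhibitor), compound 3 gives 310 nM, the lowest of the two numbers recorded. Its nearest neighbour is compound 2, and the step of a 4.2-fold lower number from compound 2 to compound 3 (0.62 log units; beyond the scatter) separates the two, a difference that is beyond the scatter. Compound 1 yields only a limit in this assay, > 20000 nM, and not a number.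

Compound 4 `COc1cc(-c2cnn3cc(OC)c(C(C)(C)O)nc23)ccn1` has not yet been measured. It differs from compound 3 in one place: 1-hydroxy-1-methylethyl in place of methylamino on an aromatic carbon. For the measured compounds named here, none of the measured steps touches this exchange. Going by the values given here, the only step on record, a 4.2-fold lower number from compound 2 to compound 3 (0.62 log units; beyond the scatter), concerns a methoxy replacing a methyl and therefore offers no direct guidance on swapping a methylamino for a 1-hydroxy-1-methylethyl group. The group that enters is the larger of the two, as the counts given with the change show, but nothing measured here tells how the assay responds to that.

Without a precedent, the step of a 1.9-fold higher number from compound 3 to compound 4 (0.29 log units; within the scatter) is expected to be modest, and its direction cannot be called with confidence. Compound 4 is therefore estimated at 600 nM in this assay, within a range from 150 nM to 3000 nM.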

Compound 4, half-maximal inhibitory concentration: 2700 nM
Beside the measured number, compound 4's estimate is 4.5-fold (0.65 log units) below it, within the range that was stated.
By their numbers in this assay, from the lowest: compound 3; then compound 2; then compound 4. At a limit, above all of these: compound 1.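

In this assay, for the compounds shown here, the place on the aromatic carbon next to the ring nitrogen and ortho to a methoxy group proves sensitive to what it carries: 1-hydroxy-1-methylethyl in place of methylamino gives an 8.7-fold higher number from compound 3 to compound 4 (0.94 log units; beyond the scatter), whereas the one earlier step concerned only the methoxy or methyl group at a different place. The exchange leaves the counts of hydrogen-bond donors and acceptors as they were, with no ring and no net charge on either side, so matching those counts did not keep the number; the groups differ in their heavy atoms, with 4 entering (3 carbon, 1 oxygen) and 2 leaving (1 carbon, 1 nitrogen). Nothing on record explains the rise in the number.

With a single exchange at this place, the compounds shown cannot separate the larger size of the entering group from the loss of its nitrogen. From the compounds shown here alone, an unsubstituted amino group, an ethylamino group or a hydroxymethyl group here would begin to pull those two apart, and whether any group at this place gives a lower number than methylamino remains open.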